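Demethylation of the aryl ether in compound 2

This account rests on a few compounds, and the source may have more. Where it says the series, first, only, none or still open, it means among the compounds named here.

In a functional assay on HT-29 cells (Homo sapiens) for inhibition, read by sulforhodamine B assay, with a stated time of 48 h, tested at 10 uM (a lower number here means a stronger effect, a higher number a weaker effect of the compound at the concentration tested), compound 1 `COc1cc(Cl)cc(-c2nn(-c3cccc(NC(=O)Nc4cccc(C(F)(F)F)c4)c3)cc2-c2ccncc2)c1` gives 5.75%. Compound 2 `COc1cc(Cl)cc(-c2nn(-c3cccc(NC(=O)Nc4ccc(Cl)c(C(F)(F)F)c4)c3)cc2-c2ccncc2)c1` gives 5.57% in this assay. Among the compounds with values here, compound 2 holds the lowest of the two numbers, with compound 1 its nearest neighbour; the single measured step, a number 0.2 percentage points lower from compound 1 to compound 2 (within the scatter), stays within the scatter. Compound 3 `O=C(Nc1cccc(-n2cc(-c3ccncc3)c(-c3cc(O)cc(Cl)c3)n2)c1)Nc1ccc(Cl)c(C(F)(F)F)c1` differs from compound 2 in one place: hydrogen in place of methyl on an oxygen on an aromatic ring. Within the data shown here, no measured step touches the oxygen on the aromatic ring; the one step in hand does not bear on this change, and the two measured compounds show only that one exchange of hydrogen for chloro kept this assay within the scatter. With nothing pointing in either direction, the expectation for compound 3 in this assay is a step of a number 0.4 percentage points higher from compound 2 to compound 3 (within the scatter), none beyond the scatter. Compound 3 is therefore estimated at 6%, with a range from 0% to 20%.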

Compound 3, a percentage reported as activity, at one concentration (the size of the read-out at that concentration, not a potency): 35.3%
The estimate for compound 3 lay 29.3 percentage points below the measured number; measured number outside the range, above it.
By their numbers in this assay, from the lowest: compounds 2 and 1 (each within the scatter of the next); then compound 3.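

In this assay, the change from methoxy to hydroxy on the 3-chloro-5-methoxyphenyl group gives a number 29.7 percentage points higher from compound 2 to compound 3 (beyond the scatter), a weaker effect at the concentration tested. Within the data shown here, the earlier exchange of hydrogen for chloro, a number 0.2 percentage points lower from compound 1 to compound 2 (within the scatter), stayed within the scatter, so the oxygen on the aromatic ring is the only place in these compounds where a single change has moved this read-out beyond the scatter. No measured property of these compounds bears on this step.

The compounds shown carry only methoxy and hydroxy on this ring position, so it remains open whether an ethoxy group, an amine or a fluoro substituent would keep the effect of compound 2 or follow compound 3. As far as these compounds go, it is also open whether the same methoxy to hydroxy change would give a similar step from compound 1, which lacks the added chloro.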